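The source may report more compounds than this note shows. Statements on the series, on what has been measured and on what is new or still open speak of the compounds shown alone.

Measured so far in an ADME assay on L6 cells (Rattus norvegicus) for cytotoxicity, read by resazurin assay, with a stated time of 70 h; a lower number here means a stronger inhibitor, a higher number a weaker inhibitor:
compound 1 `N=C(N)c1ccc2oc(-c3cccc(OCCCCCCOc4ccccc4)c3)cc2c1` gives 3100 nM;
compound 2 `N=C(N)c1ccc2cc(-c3cccc(OCCCOc4ccccc4)c3)oc2c1` gives 19800 nM;
compound 3 `CC(C)NC(=N)c1ccc2cc(-c3cccc(OCCCOc4ccccc4)c3)oc2c1` gives 82300 nM.

Among these three, compound 3 stands at the highest number, so it is the weakest inhibitor of cell growth in this assay. Among the compounds with values here, the one measured step that changes only one place, a 4.2-fold higher number from compound 2 to compound 3 (0.62 log units; beyond the scatter), added an isopropyl on an amine nitrogen and raised the number.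

Compound 4 `c1ccc(OCCCOc2cccc(-c3cc4ccc(C5=NCCN5)cc4o3)c2)cc1` is not yet measured. It differs from compound 3 in one place: a group of 5 heavy atoms (3 carbon, 2 nitrogen; one five-membered non-aromatic ring with 2 hetero atoms) in place of a group of 6 heavy atoms (4 carbon, 2 nitrogen; no ring), on an aromatic carbon. Within the data shown here, no measured pair shows exactly this exchange, so the expectation rests loosely on the step that separates compound 2 and compound 3. Compound 4 is therefore expected to give 40000 nM, within a range from 12000 nM to 130000 nM. This estimate means an expected step of a 2.1-fold lower number from compound 3 to compound 4 (0.31 log units; beyond the scatter), a modest lowering that remains uncertain.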

Compound 4, half-maximal inhibitory concentration: 10100 nM
Compound 4: middle estimate off by 4.0-fold (0.60 log units), on the high side; measured number below the stated range.
By their numbers in this assay, from the lowest: compound 1; then compounds 4 and 2 (each within the scatter of the next); then compound 3.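

In this assay, the five-membered non-aromatic ring on this aromatic carbon does not carry the rise that the isopropyl brought: replacing the open group of compound 3 gives the step (an 8.1-fold lower number from compound 3 to compound 4 (0.91 log units; beyond the scatter)). Against the smaller open group, the step (a 2.0-fold lower number from compound 2 to compound 4 (0.29 log units; within the scatter)) shows that the ring and the unsubstituted group cannot be told apart here. No measurement shown gives a cause for either step. Still open, as far as these compounds go, is where a six-membered ring with two nitrogens, or a smaller ethyl group on the amine nitrogen, would fall. Also open, from the compounds shown here alone, is whether the ring behaves the same way with a longer chain.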